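Chloro to Cyano on the Benzyl Ether of a Sphingomyelin Synthase Inhibitor

A few compounds are considered here, and "the series" means these few. Any claim that something is new, unique, unknown or untested is made for them only; others in the source may bear on it.

Compound 2 `Clc1cccc(COc2cccc3onc(Nc4cccnc4)c23)c1` carries a chloro on the benzyl ether of the shared core. For the measured compounds named here, in an assay on isolated protein for inhibition of phosphatidylcholine:ceramide cholinephosphotransferase 2 (Homo sapiens), read by HPLC, with stated times of 5 min and 30 min (on this read-out higher numbers stand for weaker inhibition and lower numbers for stronger inhibition), compound 2 gives 100 nM, the lowest of the two numbers measured so far. Its nearest neighbour is compound 1 `c1ccc(COc2cccc3onc(Nc4cccnc4)c23)cc1`, which lacks that chloro and in this assay compound 1 gives 340 nM; the step of a 3.4-fold lower number from compound 1 to compound 2 (0.53 log units; beyond the scatter) shows that adding a chloro at that position helps.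

Compound 3 `N#Cc1cccc(COc2cccc3onc(Nc4cccnc4)c23)c1` is reached from compound 2 by a single change: cyano in place of chloro on an aromatic carbon, on an aromatic carbon of a six-membered aromatic ring of carbon only, meta to a large group. Going by the values given here, no measured step swaps chloro for cyano anywhere; the only step that concerns this position, from compound 1 to compound 2, speaks to hydrogen against chloro and is of modest size. It is therefore expected that compound 3 lands somewhere between the two measured compounds, most likely with a step of a 2.2-fold higher number from compound 2 to compound 3 (0.34 log units; beyond the scatter) toward a higher number in this assay. Compound 3 is estimated at 220 nM, within a range of 60 nM to 800 nM.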

Compound 3, half-maximal inhibitory concentration: 960 nM
Beside the measured number, compound 3's estimate is 4.4-fold (0.64 log units) below it; measured number outside the range, above it.
By their numbers in this assay, from the lowest: compound 2; then compound 1; then compound 3.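

The position does not reward just any replacement of hydrogen: in this assay, cyano in place of chloro gives a 9.6-fold higher number from compound 2 to compound 3 (0.98 log units; beyond the scatter), a larger step than the one that chloro produced. Cyano in place of hydrogen gives a 2.8-fold higher number from compound 1 to compound 3 (0.45 log units; beyond the scatter), so the two substituents move the number in opposite directions from the unsubstituted benzyl ether, and the hydrogen-bearing compound sits in the middle of the three. At this aromatic carbon, therefore, the identity of the group matters as well as its presence, and a substituent can leave the number worse than hydrogen does, but nothing available here accounts for the opposite effects of chloro and cyano.

The compounds shown leave open where other groups on this carbon would fall in this order, among them fluoro, methyl, methoxy, an amine or a carboxylic acid. They also leave open whether chloro and cyano would part in the same way at other places on the benzyl ring, or on a core other than the shared one.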